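This account rests on a few compounds, and the source may have more. Where it says the series, first, only, none or still open, it means among the compounds named here.

Compound 1, `CCOC(=O)C1CCN(C(=O)CN2CN(c3ccccc3)C3(CCN(C(=O)c4ccc(C5CCCCC5)cc4)CC3)C2=O)CC1`, gives 900 nM in an assay on HEK293 cells for displacement of a labelled ligand from NPC1-like intracellular cholesterol transporter 1 (Homo sapiens); a lower number here means a stronger inhibitor, a higher number a weaker inhibitor.
Compound 2, `CC(C)(C)OC(=O)NC1CCN(C(=O)CN2CN(c3ccccc3)C3(CCN(C(=O)c4ccc(C5CCCCC5)cc4)CC3)C2=O)CC1`, gives 4800 nM in this assay.
Compound 3, `O=C(CN1CN(c2ccccc2)C2(CCN(C(=O)c3ccc(C4CCCCC4)cc3)CC2)C1=O)N1CCCCC1`, gives 1100 nM in this assay.

Among these three, compound 3 holds the second highest number. It sits within the scatter of compound 1, as a 1.2-fold higher number from compound 1 to compound 3 (0.09 log units; within the scatter) shows, and clearly apart from compound 2, as a 4.4-fold lower number from compound 2 to compound 3 (0.64 log units; beyond the scatter) shows.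

Compound 4, `CCOC(=O)C1CCCN(C(=O)CN2CN(c3ccccc3)C3(CCN(C(=O)c4ccc(C5CCCCC5)cc4)CC3)C2=O)C1`, is the next step from compound 3. The change is ethoxycarbonyl in place of hydrogen on a saturated ring carbon. Two measured steps speak to it. The closest is a 1.2-fold higher number from compound 1 to compound 3 (0.09 log units; within the scatter): there the ethoxycarbonyl group was removed from the same kind of ring, and the number barely moved. Compound 4 reverses that move, though the group now enters at a saturated ring carbon two ring bonds from the ring nitrogen rather than at the carbon it occupied in compound 1. The other step, a 4.4-fold lower number from compound 2 to compound 3 (0.64 log units; beyond the scatter), shows that a different group on that ring did shift the number beyond the scatter, so not every substituent there is neutral.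

On balance compound 4 is expected to stay close to compound 3, with an estimated step of a 1.1-fold lower number from compound 3 to compound 4 (0.04 log units; within the scatter), within the scatter or only just beyond it. The expected value for compound 4 in this assay is 1000 nM, in a range from 400 nM to 2600 nM.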

Compound 4, half-maximal inhibitory concentration: 4200 nM
For compound 4 the middle estimate is 4.2-fold (0.62 log units) below the measured one, and the stated range ends below it.
By their numbers in this assay, from the lowest: compounds 1 and 3 (each within the scatter of the next); then compounds 4 and 2 (each within the scatter of the next).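

In this assay the ethoxycarbonyl group proves not to be neutral on this ring: entering on a saturated ring carbon two ring bonds from the ring nitrogen, it gives a 3.8-fold higher number from compound 3 to compound 4 (0.58 log units; beyond the scatter) and so stands apart from a 1.2-fold higher number from compound 1 to compound 3 (0.09 log units; within the scatter) where the same group and hydrogen were exchanged without a change beyond the scatter. The direct comparison of the two placements, 3-(ethoxycarbonyl)piperidin-1-yl in place of 4-(ethoxycarbonyl)piperidin-1-yl, gives a 4.7-fold higher number from compound 1 to compound 4 (0.67 log units; beyond the scatter) with the group itself unchanged. Among these compounds, then, the number depends on which ring carbon carries the ethoxycarbonyl group and not merely on its presence, which the earlier steps could not show.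

Whether this ring carbon disfavours any added group or ethoxycarbonyl in particular stays open, since no carboxylic acid, primary amine or hydroxymethyl group at this place is among the compounds shown. No measurement given here accounts for the difference between the two placements.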